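The compounds below may be only part of what the source reports. "The series", "measured", "known", "first", "only" and "open" are said of these compounds alone.

Measured compounds:
compound 1, `CN1CCN(S(=O)(=O)Cc2noc3ccccc23)CC1`, 57 mg/kg;
compound 2, `CC(C)NS(=O)(=O)Cc1noc2ccc(Br)cc12`, 22 mg/kg.

Both numbers come from a functional assay on the whole organism (strain STD-dd) with Mus musculus as the target, in the maximal electroshock model, with a stated time of 2 h; a higher number here means that more compound is needed for the effect, a lower number that less compound is needed. Compound 2 holds the lower of the two numbers, and the gap to compound 1 lies beyond the usual scatter. Compound 3 `CN1CCN(S(=O)(=O)Cc2noc3ccc(Br)cc23)CC1` differs from compound 2 by 4-methylpiperazin-1-yl in place of isopropylamino on a sulfonyl sulfur. Going by the values given here, no measured pair shows this change alone, so its size is uncertain. A rise in the number is expected, because compound 1, which carries the same 4-methylpiperazin-1-yl group, gives 57 mg/kg in this assay. Compound 3 is therefore estimated at 38 mg/kg, between 17 mg/kg and 85 mg/kg, an expected step of a 1.7-fold higher number from compound 2 to compound 3 (0.24 log units; within the scatter).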

Compound 3, dose for half-maximal effect: 88 mg/kg
Estimate against measurement, compound 3: 2.3-fold (0.36 log units) below; the measured number lies above the stated range.
By their numbers in this assay, from the lowest: compound 2; then compounds 1 and 3 (each within the scatter of the next).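

In this assay, the change at the sulfonyl sulfur now stands alone: 4-methylpiperazin-1-yl in place of isopropylamino gives a 4.0-fold higher number from compound 2 to compound 3 (0.60 log units; beyond the scatter), with the rest of the structure held constant. Bromo in place of hydrogen on an aromatic carbon, by contrast, gives a 1.5-fold higher number from compound 1 to compound 3 (0.19 log units; within the scatter), so this pair shows no separable effect of bromo with 4-methylpiperazin-1-yl in place. No measurement available here explains the step at the sulfur. Going by these compounds, it remains open whether an unsubstituted amino group or a morpholin-4-yl group on the sulfonyl sulfur would give a number near that of compound 2. On these data alone, the bromo step also remains unknown with isopropylamino on the sulfur.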